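A Ring Exchange on the Carbonyl of Compound 1

This account rests on a few compounds, and the source may have more. Where it says the series, first, only, none or still open, it means among the compounds named here.

Among the compounds with values here, in a functional assay on HeLa cells (Homo sapiens) for cytotoxicity, read by LDH release, with a stated time of 48 h (on this read-out lower numbers stand for stronger inhibition and higher numbers for weaker inhibition), compound 1 `O=C(COc1c(F)cc(C(=O)c2ccc(F)cc2)cc1Cl)NNC(=O)c1ccc(=O)oc1` gives 60100 nM, the higher of the two numbers measured so far, while compound 2 `Cc1ccc(C(=O)c2cc(F)c(OCC(=O)NNC(=O)c3ccc(=O)oc3)c(Cl)c2)cc1` gives 26900 nM. Compound 3 `Cn1cnc(C(=O)NNC(=O)COc2c(F)cc(C(=O)c3ccc(F)cc3)cc2Cl)c1` keeps the core of compound 1 but carries a new group: a group of 6 heavy atoms (4 carbon, 2 nitrogen; one five-membered aromatic ring with 2 hetero atoms) in place of a group of 7 heavy atoms (5 carbon, 2 oxygen; one six-membered aromatic ring with 1 hetero atom), on a carbonyl carbon. Within the data shown here, the only measured step, a 2.2-fold lower number from compound 1 to compound 2 (0.35 log units; beyond the scatter), is modest and lies on an aromatic carbon, so no measured step touches this carbonyl carbon. No change beyond the scatter is therefore expected, and the estimated step is a 1.2-fold higher number from compound 1 to compound 3 (0.07 log units; within the scatter). For compound 3 the expected value is 70000 nM, with an estimated range from 25000 nM to 190000 nM.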

Compound 3, half-maximal inhibitory concentration: 40900 nM
Estimate against measurement, compound 3: 1.7-fold (0.23 log units) above; low and high end bracket the measured number.
By their numbers in this assay, from the lowest: compounds 2, 3 and 1 (each within the scatter of the next, the first and the last beyond it).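

Within the data shown here, the first step at this carbonyl carbon, a 1.5-fold lower number from compound 1 to compound 3 (0.17 log units; within the scatter) in this assay, stays within the scatter. Whereas the earlier step lay on an aromatic carbon, this one shows that a five-membered aromatic ring, 1-methyl-1H-imidazol-4-yl, can replace the six-membered one here with no change beyond the scatter. Nothing available explains this outcome. On these data alone, whether an amine or a longer alkyl chain on this carbonyl carbon would shift the number remains open. So does whether methyl in place of fluoro on the aromatic carbon would act the same way in compound 3.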